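Anilide halogen pattern: from compound 3 to compound 4

The source may hold more compounds than are shown below. What is called first, only, known or untested is meant among the compounds shown, and "the series" means these compounds.

The series keeps one shared core and varies the aryl group on the amide-type nitrogen. In a functional assay on MGC-803 cells (Homo sapiens) for inhibition, read by MTT assay, with a stated time of 72 h (a higher number here means a weaker inhibitor, a lower number a stronger inhibitor), compound 1 `O=C(CSc1nc(Nc2ccccc2)c2ccccc2n1)Nc1ccccc1Cl` gives 24800 nM. Compound 2 `O=C(CSc1nc(Nc2ccccc2)c2ccccc2n1)Nc1ccccc1Br` gives 18600 nM in this assay, and the step of a 1.3-fold lower number from compound 1 to compound 2 (0.12 log units; within the scatter) stays within the scatter. Compound 3 `O=C(CSc1nc(Nc2ccccc2)c2ccccc2n1)Nc1ccc(F)cc1` reaches only a limit of this assay, > 50000 nM, so its position is known as a floor and not as a number. Against the measured pair the steps read an at least 2.0-fold higher number from compound 1 to compound 3 (0.30 log units; that floor lies within the scatter) and an at least 2.6-fold higher number from compound 2 to compound 3 (0.42 log units; beyond the scatter): the 4-fluorophenyl weakened inhibition relative to both 2-halophenyl anilides. the limit of > 50000 nM in this assay, at which 1 of the 3 values shown sits, marks how far this assay reached.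

Compound 4 `O=C(CSc1nc(Nc2ccccc2)c2ccccc2n1)Nc1ccc(Cl)cc1Cl` carries 2,4-dichlorophenyl in place of 4-fluorophenyl on an amide-type nitrogen. The entering 2,4-dichlorophenyl shares the 2-chlorophenyl motif of compound 1 and adds a second chloro. The two steps into compound 3 ran upward; the reverse direction is the relevant one here, while the starting point at a limit leaves the size open. A downward step to compound 4 is therefore expected, of roughly an at least 2.0-fold lower number from compound 3 to compound 4 (0.30 log units; that floor lies within the scatter). For compound 4 the expected value in this assay is 25000 nM, with a range from 8000 nM to 70000 nM.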

Compound 4, half-maximal inhibitory concentration: 12300 nM
For compound 4 the middle estimate is 2.0-fold (0.31 log units) above the measured one, within the range that was stated.
By their numbers in this assay, from the lowest: compounds 4, 2 and 1 (each within the scatter of the next). At a limit, above all of these: compound 3.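

In this assay the change from 4-fluorophenyl to 2,4-dichlorophenyl on the amide-type nitrogen gives the first step into compound 4 that is read as beyond the scatter (an at least 4.0-fold lower number from compound 3 to compound 4 (0.60 log units; beyond the scatter)), so a dihalogenated aryl group at this position sits clearly on the lower side of compound 3. The second chloro adds no separable change to the 2-chlorophenyl anilide (a 2.0-fold lower number from compound 1 to compound 4 (0.30 log units; within the scatter)), and the 2-bromophenyl anilide is likewise not separated from compound 4 (a 1.5-fold lower number from compound 2 to compound 4 (0.18 log units; within the scatter)), leaving compounds 1, 2 and 4 as one group within the scatter. The step out of compound 3 remains a floor and its full size stays unknown, because compound 3 stands at a limit of this assay and not at a number: the limit of > 50000 nM in this assay, at which 1 of the 4 values shown sits.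

Whether any halogen is needed on this aryl group stays open, since an unsubstituted phenyl is not among the compounds shown. Equally open, from the compounds shown here alone, is how this position responds to a group other than a halogen, such as a methoxy, an amine or a carboxylic acid on the ring.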